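A few compounds are considered here, and "the series" means these few. Any claim that something is new, unique, unknown or untested is made for them only; others in the source may bear on it.

Measured so far:
compound 1 `COc1ccc(-c2cc(-c3ccc(S(N)(=O)=O)cc3)cnc2N)cn1` — in a physicochemical assay for solubility, read by nephelometry, measured as kinetic solubility, at pH 2 (on this read-out higher numbers stand for higher solubility and lower numbers for lower solubility), compound 1 gives > 100 ug/mL, a limit of the assay rather than a number.
compound 2 `COc1ccc(-c2cc(-c3ccc(S(C)(=O)=O)cc3C(F)(F)F)cnc2N)cn1` — in this assay compound 2 gives > 100 ug/mL, again a limit of the assay.

For the measured compounds named here, compound 1 therefore stands at the top of what this assay can report; both values shown sit at the same ceiling, (the limit of > 100 ug/mL in this assay, at which 2 of the 2 values shown sit), so no order between compound 1 and compound 2 can be read from them, and no measured step between neighbours exists in this set.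

The next compound, compound 3 `CNC(=O)c1ccc(-c2cnc(N)c(-c3ccc(OC)nc3)c2)cc1`, keeps the shared core of compound 1 and changes one group: methylcarbamoyl in place of sulfamoyl on an aromatic carbon. The leaving and entering groups are of the same size and are both neutral, so nothing here points to a large shift in either direction; the expectation is a change of no more than the scatter, most likely a value again at the ceiling of this assay.

Estimated step from compound 1 to compound 3: a number no higher from compound 1 to compound 3 (the limit leaves the size open). For compound 3 the expected solubility in this assay is 100 ug/mL, within a range of 40 ug/mL to 200 ug/mL, with a fair chance that only a limit is reported.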

Compound 3, solubility: 50 ug/mL
Compound 3: middle estimate off by 2.0-fold (0.30 log units), on the high side; the range from low to high includes it.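

In this assay, for the compounds shown here, methylcarbamoyl in place of sulfamoyl on an aromatic carbon, para to a large group, gives an at least 2.0-fold lower number from compound 1 to compound 3 (0.30 log units; that floor lies within the scatter), the first step that can be read at all, though only as a floor. Compound 1 gives > 100 ug/mL, which is a limit of the assay. Compound 3 is the only compound shown that carries a number rather than a limit, so the series now has one reference point off the ceiling of the read-out, while the true size of this step, and whether it exceeds the scatter, stays undetermined: the limit of > 100 ug/mL in this assay, at which 2 of the 3 values shown sit.

The compounds shown do not separate the carbonyl from the methyl on its nitrogen, and a plain carboxamide or a carboxylic acid on the same aromatic carbon would be the comparison that tells these two apart. Also open is whether methylcarbamoyl in place of sulfamoyl gives a step of like size on other members of the series, as this is the only pair shown that differs in one place.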